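The compounds below may be only part of what the source reports. "The series", "measured", "known", "first", "only" and "open" are said of these compounds alone.

Of the compounds shown here, three have so far been measured in a functional assay on SiHa cells (Homo sapiens) for cytotoxicity, read by MTT assay, with a stated time of 48 h; a lower number here means a stronger inhibitor, a higher number a weaker inhibitor. Compound 1 `CCCCCCCCNC(=O)[C@@H](NC(=O)c1cc2ccccc2o1)[C@@H](C)O` and compound 2 `CCCCCCCCCCCCNC(=O)[C@@H](NC(=O)c1cc2ccccc2o1)[C@@H](C)O` share one core and differ only in the length of the chain on the amide-type nitrogen. In this assay compound 1 gives 66500 nM, while compound 2 gives 12900 nM. That change, (butyl in place of hydrogen on a saturated chain carbon, eight bonds along the chain from an amide-type nitrogen), brought a 5.2-fold lower number from compound 1 to compound 2 (0.71 log units; beyond the scatter). Compound 3 `CCCCCCCCCCCCCCNC(=O)[C@@H](NC(=O)c1ccccc1)[C@@H](C)O` carries a different core; the difference between the two cores is not broken down here. For compound 3 this assay reported only a limit, > 200000 nM, which is the limit of > 200000 nM in this assay, at which 1 of the 3 values shown sits. Compound 4 `CCCCCCCCCCCCCCCCCCNC(=O)[C@@H](NC(=O)c1ccccc1)[C@@H](C)O` has not yet been measured. It differs from compound 3 by butyl in place of hydrogen on a saturated chain carbon, ten or more bonds along the chain from an amide-type nitrogen, the same kind of change as that between compound 1 and compound 2. Since compound 3 offers only a limit, the starting point is uncertain. For compound 4 the expected step is an at least 1.3-fold lower number from compound 3 to compound 4 (0.12 log units; that floor lies within the scatter), resting on the lowering seen in a 5.2-fold lower number from compound 1 to compound 2 (0.71 log units; beyond the scatter). For compound 4 the estimate in this assay is 150000 nM, expected to lie between 40000 nM and 400000 nM.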

Compound 4, half-maximal inhibitory concentration: 38200 nM
For compound 4 the middle estimate is 3.9-fold (0.59 log units) above the measured one, and the stated range ends above it.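

In this assay, butyl in place of hydrogen on a saturated chain carbon lowers the number on the second core as it did on the first, and the new result is an at least 5.2-fold lower number from compound 3 to compound 4 (0.71 log units; beyond the scatter). The value for compound 3, > 200000 nM, is a limit and not a number, so this step has a floor but no exact size. The direction of the change therefore carried over from one core to the other in this one pair, but the data do not show that the size carried over, and two pairs do not establish a rule for the series: the same change on two cores in this assay, a 5.2-fold lower number (0.71 log units; beyond the scatter) from compound 1 to compound 2 and an at least 5.2-fold lower number (0.71 log units; beyond the scatter) from compound 3 to compound 4; the limit leaves it open whether they differ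

The compounds shown leave open whether a longer chain on the amide-type nitrogen would lower the number further on either core. They also leave open how an amine or a carboxylic acid in place of the butyl would read in this assay, and how the two cores compare when they carry the same chain.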